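Extending the amine chain on compound 1: a cytotoxicity estimate

The compounds below may be only part of what the source reports. "The series", "measured", "known", "first", "only" and "open" are said of these compounds alone.

Measured compounds:
- compound 1, `Cc1ccc2oc(-c3ccc(NC(=O)CN4CCN(CCN(C)C)CC4)c(C)c3)nc2c1`: 5670 nM
- compound 2, `Cc1cc(-c2nc3cc(F)ccc3o2)ccc1NC(=O)CN1CCN(CCN(C)C)CC1`: 62100 nM

Both compounds were tested in an ADME assay on NIH3T3 cells (Mus musculus) for cytotoxicity, read by MTT assay, with a stated time of 24 h; on this read-out lower numbers stand for stronger inhibition and higher numbers for weaker inhibition. Compound 1 gives the lowest of the two numbers; compound 2, which differs from it by a fluoro in place of a methyl on an aromatic carbon, sits far higher, as the step of an 11-fold higher number from compound 1 to compound 2 (1.04 log units; beyond the scatter) shows.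

Compound 3, `Cc1ccc2oc(-c3ccc(NC(=O)CN4CCN(CCCN(C)C)CC4)c(C)c3)nc2c1`, has not yet been measured. It differs from compound 1 only in the side chain on the ring amine: (dimethylamino)methyl in place of dimethylamino on a saturated chain carbon, two bonds along the chain from an amine nitrogen in a ring. For the measured compounds named here, the one measured step, from compound 1 to compound 2, concerns a change on an aromatic ring, not on this chain, so it offers no direct guide to the present change. With nothing to go on but the value of compound 1 itself, compound 3 is expected to fall close to it, with a step of a 1.0-fold higher number from compound 1 to compound 3 (0.00 log units; within the scatter) that stays within the scatter. On that basis compound 3 is estimated at 5700 nM, with a range from 2000 nM to 16000 nM.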

Compound 3, half-maximal inhibitory concentration: 13200 nM
Beside the measured number, compound 3's estimate is 2.3-fold (0.36 log units) below it; low and high end bracket the measured number.
By their numbers in this assay, from the lowest: compound 1; then compound 3; then compound 2.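

Moving from dimethylamino to (dimethylamino)methyl on the side chain of the ring amine changes the result in this assay, giving a 2.3-fold higher number from compound 1 to compound 3 (0.37 log units; beyond the scatter). This shows that the saturated chain, two bonds along from the amine nitrogen in the ring, is not a silent position: a change that adds only a single heavy atom, with the hydrogen-bond donor and acceptor counts unchanged, still moves the number beyond the usual scatter, although by less than the aromatic change in an 11-fold higher number from compound 1 to compound 2 (1.04 log units; beyond the scatter). Nothing at hand accounts for the shift, so the data record its direction and size but not its cause.

For the compounds shown here, two compounds on this chain give only one step, so they cannot show whether the number keeps climbing with a longer chain such as 2-(dimethylamino)ethyl or 3-(dimethylamino)propyl, or whether it levels off or falls back. Going by these compounds, it also remains open whether the end of the chain needs to be a dimethylamino group at all, or whether a ring amine such as morpholine or a simple hydroxyl there would give a similar number, and whether the chain change and the fluoro change would add up when combined in one compound.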